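This account rests on a few compounds, and the source may have more. Where it says the series, first, only, none or still open, it means among the compounds named here.

Values in an assay on isolated protein for inhibition of biotin--protein ligase (Homo sapiens), read by scintillation counting, with a stated time of 10 min (on this read-out higher numbers stand for weaker inhibition and lower numbers for stronger inhibition), for the measured members of the series:

compound 1 `O=C1N[C@H]2[C@H](CS[C@H]2CCCCCc2cn(Cc3cccc(O)c3)nn2)N1` — a limit of the assay, > 16000 nM.
compound 2 `Nc1ccccc1Cn1cc(CCCCC[C@@H]2SC[C@@H]3NC(=O)N[C@@H]32)nn1` — a limit of the assay, > 16000 nM.
compound 3 `O=C1N[C@H]2[C@H](CS[C@H]2CCCCCc2cn(Cc3cccc(C(F)(F)F)c3)nn2)N1` — a limit of the assay, > 16000 nM.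

For the measured compounds named here, compound 3 therefore stands at the same limit as every other value recorded so far, since (the limit of > 16000 nM in this assay, at which 3 of the 3 values shown sit); no member has yet returned a number. The three steps among them, a step that the two limits leave unreadable from compound 1 to compound 2, a step that the two limits leave unreadable from compound 1 to compound 3 and a step that the two limits leave unreadable from compound 2 to compound 3, are all left unreadable by the two limits, so none of them tells how the aryl group on the saturated chain carbon bound to the aromatic nitrogen moves the read-out.

Compound 4 `O=C1N[C@H]2[C@H](CS[C@H]2CCCCCc2cn(Cc3ccccc3Cl)nn2)N1` takes the change (2-chlorophenyl in place of 3-(trifluoromethyl)phenyl on a saturated chain carbon bound to an aromatic nitrogen). Each measured step bears on it only as a variation of the same aryl group, and each is of unreadable size; no direction can be drawn from them. The expectation for compound 4 is thus a step that the limit leaves unreadable from compound 3 to compound 4, which is to say nothing readable in this assay. Compound 4 is estimated at 30000 nM, within 16000 nM to 100000 nM, most probably reported again as a limit.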

Compound 4, inhibition constant: > 16000 nM
Compound 4: a limit, no number; the forecaster's own chance of this, stated with the estimate: 85%; the middle value does not contradict the limit.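

Compound 4 adds no readable step in this assay, and the steps linking it to compound 1, compound 2 and compound 3 all stay unreadable, since each compound gives only a limit: the limit of > 16000 nM in this assay, at which 4 of the 4 values shown sit.

The compounds shown leave open how the aryl group on the saturated chain carbon bound to an aromatic nitrogen moves the read-out.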